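This account rests on a few compounds, and the source may have more. Where it says the series, first, only, none or still open, it means among the compounds named here.

Measured so far:
- compound 1, `CC(=O)c1cnc(N2CCC(c3coc4c(N5CCc6cc(S(C)(=O)=O)ccc65)ncnc34)CC2)nc1`: 78 nM
- compound 3, `CC(C)(C)OC(=O)N1CCC(c2coc3c(Nc4ccc(S(C)(=O)=O)cc4F)ncnc23)CC1`: 129 nM
- compound 2, `CC(C)(C)OC(=O)N1CCC(c2c[nH]c3c(Nc4ccc(S(C)(=O)=O)cc4F)ncnc23)CC1`: a limit, > 1000 nM

In a functional assay on cells for agonist activity at Glucose-dependent insulinotropic receptor (Homo sapiens), read by a luciferase reporter, with a stated time of 4 h (on this read-out higher numbers stand for an effect only at larger amounts of compound and lower numbers for an effect already at smaller amounts), compound 1 gives 78 nM, the lowest of the two numbers shown. Compound 3 gives 129 nM in this assay, and its gap to compound 1 is within the scatter, so the two cannot be told apart. For compound 2 this assay reports only a limit and no number, > 1000 nM. One of the three values shown thus sits at the limit of > 1000 nM in this assay, at which 1 of the 3 values shown sits.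

Compound 4, `CCc1cnc(N2CCC(c3coc4c(N5CCc6cc(S(C)(=O)=O)ccc65)ncnc34)CC2)nc1`, has not yet been measured in this assay. It departs from compound 1 at a single point: ethyl in place of acetyl on an aromatic carbon. Among the compounds with values here, no step between measured compounds covers this kind of change, so no measured gap is available to lean on.

The expected step is a 2.3-fold higher number from compound 1 to compound 4 (0.36 log units; beyond the scatter), a modest move toward a higher number that is estimated to lie beyond the scatter without being large. For compound 4 the estimate in this assay is 180 nM, with a range from 60 nM to 600 nM. The result will show whether the ethyl in place of the acetyl holds the activity of compound 1 or moves it.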

Compound 4, half-maximal effective concentration: 41 nM
For compound 4 the middle estimate is 4.4-fold (0.64 log units) above the measured one; measured number below the stated range.
By their numbers in this assay, from the lowest: compounds 4, 1 and 3 (each within the scatter of the next, the first and the last beyond it). At a limit, above all of these: compound 2.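

The change from 5-acetylpyrimidin-2-yl to 5-ethylpyrimidin-2-yl gives a 1.9-fold lower number from compound 1 to compound 4 (0.28 log units; within the scatter) in this assay, so compound 1 and compound 4 cannot be told apart. Within the data shown here, this is the first step read at this position, on an aromatic carbon para to a large group, and it shows that the activity of compound 1 holds when the acetyl, with its carbonyl and its hydrogen-bond acceptor, gives way to an ethyl that carries no hydrogen-bond acceptor. The compounds shown offer no measured property that accounts for this step.

As far as these compounds go, with only acetyl and ethyl at this position, the range of groups it accepts stays open: an amine, a carboxylic acid or a longer chain such as butyl on the same carbon would show whether the activity in this assay still holds or moves. Among these compounds, also open is whether the same change behaves alike on another background, since compound 2 and compound 3 differ from compound 4 in more than one place and give no step to compare.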